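This account rests on a few compounds, and the source may have more. Where it says the series, first, only, none or still open, it means among the compounds named here.

Measured so far:
- compound 1, `CCOC(=O)c1cnc(C(F)(F)F)nc1NN1C(=O)C=C(C)C1=O`: 1000 nM
- compound 2, `CCOC(=O)c1cnc(SC)nc1NN1C(=O)C=C(C)C1=O`: 200 nM
- compound 3, `CCOC(=O)c1cnc(-c2ccc(C)s2)nc1NN1C(=O)C=C(C)C1=O`: 200 nM

All three share a core and differ only in the group on an aromatic carbon. In a functional assay on Jurkat cells for inhibition of nuclear factor NF-kappa-B complex (Homo sapiens) (on this read-out higher numbers stand for weaker inhibition and lower numbers for stronger inhibition), compound 1 gives 1000 nM. Compound 2 stands level with compound 3 at the digits shown, and together they give the lowest numbers of the three; the step of a 5.0-fold lower number from compound 1 to compound 2 (0.70 log units; beyond the scatter) and the step of a 5.0-fold lower number from compound 1 to compound 3 (0.70 log units; beyond the scatter) both lie beyond the scatter, while the step of no change at the digits printed from compound 2 to compound 3 (within the scatter) does not.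

Compound 4, `CCOC(=O)c1cnc(C2CC2)nc1NN1C(=O)C=C(C)C1=O`, has not yet been measured in this assay. It differs from compound 2 by cyclopropyl in place of methylsulfanyl on an aromatic carbon. Among the compounds with values here, the measured steps that bear on this change are the two that replace trifluoromethyl, a 5.0-fold lower number from compound 1 to compound 2 (0.70 log units; beyond the scatter) and a 5.0-fold lower number from compound 1 to compound 3 (0.70 log units; beyond the scatter), and the one that swaps methylsulfanyl for a larger group, no change at the digits printed from compound 2 to compound 3 (within the scatter). Within the data shown here, no measured step involves cyclopropyl itself, so its effect is open; the only hint is that two different groups in this place gave the same number. The step from compound 2 to compound 4 is therefore expected to stay within the scatter, with a somewhat greater chance of a higher number than a lower one. The expected step is a 1.5-fold higher number from compound 2 to compound 4 (0.18 log units; within the scatter). Compound 4 is estimated to give 300 nM, with a range from 100 nM to 1000 nM.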

Compound 4, half-maximal inhibitory concentration: 1000 nM
Compound 4: middle estimate off by 3.3-fold (0.52 log units), on the low side, within the range that was stated.
By their numbers in this assay, from the lowest: compounds 2 and 3 (each within the scatter of the next); then compounds 1 and 4 (each within the scatter of the next).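

At the aromatic carbon between two ring nitrogen atoms, the shared level of compound 2 and compound 3 does not extend to every group, since in this assay cyclopropyl gives a 5.0-fold higher number from compound 2 to compound 4 (0.70 log units; beyond the scatter) and a 5.0-fold higher number from compound 3 to compound 4 (0.70 log units; beyond the scatter) so that the position proves sensitive to the group it carries. Cyclopropyl also offers no gain over the first group tried here, with no change at the digits printed from compound 1 to compound 4 (within the scatter) and so the four compounds fall into two levels: the two groups that contain sulfur, methylsulfanyl and 5-methylthiophen-2-yl, at the lower numbers and the two without sulfur, trifluoromethyl and cyclopropyl, at the higher, with no compound shown going against this split. Nothing measured here accounts for this division, and four groups cannot tell whether the sulfur matters or whether the split is a coincidence of the groups at hand.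

The compounds shown leave open whether the sulfur itself counts, a question that methoxy in place of methylsulfanyl, or phenyl in place of 5-methylthiophen-2-yl, would address directly. They also leave open how a longer chain on the sulfur, such as ethylsulfanyl, or an amine such as dimethylamino would stand at this position against these two levels.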